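The source may hold more compounds than are shown below. What is called first, only, known or untested is meant among the compounds shown, and "the series" means these compounds.

Working notes on the series. Compound 1 `CCn1c(-c2ccc(C(F)(F)F)nc2)nc2c(O[C@H]3CCN(C(=O)[C@H]4C[C@@H](OC)C4)C3)ncnc21` is the reference point. For the measured compounds named here, in an ADME assay on LLC-PK1 cells (Sus scrofa) for permeability (a higher number here means that the compound crosses the layer faster, a lower number that the compound crosses the layer more slowly), compound 1 gives 35 10^-6 cm/s, the highest of the two numbers so far, though only by a margin that means little. The nearest is compound 2 `CCn1c(-c2cnc(C)nc2)nc2c(O[C@H]3CCN(C(=O)[C@H]4C[C@@H](OC)C4)C3)ncnc21`: in this assay compound 2 gives 18 10^-6 cm/s, and the step of a 1.9-fold lower number from compound 1 to compound 2 (0.29 log units; within the scatter) swaps only the aryl group attached to the core, so on the numbers the two are not separated.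

Compound 3 `CCn1c(-c2ccc(C(F)(F)F)nc2)nc2c(O[C@H]3CCN(C(=O)N4CC(OC)C4)C3)ncnc21` is still to be measured in this assay. It differs from compound 1 in this way: 3-methoxyazetidin-1-yl in place of 3-methoxycyclobutyl on a carbonyl carbon. The count of heavy atoms, donors and acceptors is unchanged; one carbon of the four-membered ring becomes a nitrogen that sits on the carbonyl carbon.

Going by the values given here, no measured step bears on this part of the molecule. Among the compounds with values here, the only step on hand, a 1.9-fold lower number from compound 1 to compound 2 (0.29 log units; within the scatter), touches the opposite end and stayed within the scatter, so it offers no direction. With nothing to argue for a shift beyond the scatter, the expectation for compound 3 is a step of a 1.3-fold lower number from compound 1 to compound 3 (0.10 log units; within the scatter), leaning very slightly down, with an estimated value of 28 10^-6 cm/s and a range of 14 10^-6 cm/s to 50 10^-6 cm/s in this assay.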

Compound 3, apparent permeability: 33 10^-6 cm/s
Beside the measured number, compound 3's estimate is 1.2-fold (0.07 log units) below it; the range from low to high includes it.
By their numbers in this assay, from the lowest: compounds 2, 3 and 1 (each within the scatter of the next).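

In this assay, the first change shown on the carbonyl carbon, 3-methoxyazetidin-1-yl in place of 3-methoxycyclobutyl, gives a 1.1-fold lower number from compound 1 to compound 3 (0.03 log units; within the scatter), so replacing the ring carbon on the carbonyl carbon with nitrogen and losing the 2 defined stereocentres of 3-methoxycyclobutyl leaves compound 1 and compound 3 not separated. The series now has a reading at this position as well as at the aryl group, where the step was a 1.9-fold lower number from compound 1 to compound 2 (0.29 log units; within the scatter), and neither of the two single changes shown lies beyond the scatter. No measurement on hand accounts for this result.

On these data alone, whether this position tolerates larger departures remains open: a primary amine or a carboxylic acid on the four-membered ring, or a longer chain such as ethoxy or propoxy in place of the methoxy group, could still move the number beyond the scatter. It is also open whether 3-methoxyazetidin-1-yl gives the same reading when 2-methylpyrimidin-5-yl replaces 6-(trifluoromethyl)pyridin-3-yl, since the two changes are not yet shown together in one compound.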